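Swapping a Sulfanyl Chain for a Carbamoyl Chain

This account rests on a few compounds, and the source may have more. Where it says the series, first, only, none or still open, it means among the compounds named here.

In a functional assay on Raji cells (Homo sapiens) for inhibition, read by MTT assay, with a stated time of 96 h (a higher number here means that more compound is needed for the effect, a lower number that less compound is needed), compound 1 (`CC(C)Cn1c(=O)n(C)c(=O)c2c1nc(Cc1cccc3ccccc13)c(=O)n2CCCCCO`) gives 1420 nM and compound 2 (`CC(C)Cn1c(=O)n(C)c(=O)c2nc(SCCCCO)c(Cc3cccc4ccccc34)nc21`) gives 37 nM as its result. Compound 2 therefore holds the lower of the two numbers, and the gap to compound 1 lies beyond the scatter. Compound 3 (`CC(C)Cn1c(=O)n(C)c(=O)c2nc(C(=O)N(C)CCCO)c(Cc3cccc4ccccc34)nc21`) carries (3-hydroxypropyl)(methyl)carbamoyl in place of (4-hydroxybutyl)sulfanyl on an aromatic carbon, ortho to a (naphthalen-1-yl)methyl group ((3-hydroxypropyl)(methyl)carbamoyl in place of (4-hydroxybutyl)sulfanyl on an aromatic carbon). Going by the values given here, no measured pair isolates this change, so any forecast is uncertain. Among the compounds with values here, the low value of compound 2 (37 nM) leaves more room to rise than to fall, and the only other value, for compound 1 (1420 nM), is far higher. A higher number is therefore expected in this assay, with an estimated step (a 4.1-fold higher number from compound 2 to compound 3 (0.61 log units; beyond the scatter)) that lies beyond the scatter. For compound 3 the estimated value is 150 nM with an expected range from 35 nM to 650 nM as its bounds.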

Compound 3, half-maximal effective concentration: > 10000 nM
Compound 3 ended at the assay's limit (the forecaster's own chance of this, stated with the estimate: 3%); at least 66-fold (1.82 log units) between middle value and limit.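

In this assay the position on an aromatic carbon, ortho to a (naphthalen-1-yl)methyl group, turns out to be highly sensitive to this change: (3-hydroxypropyl)(methyl)carbamoyl in place of (4-hydroxybutyl)sulfanyl brings an at least 270-fold higher number from compound 2 to compound 3 (2.43 log units; beyond the scatter). Compound 3 gives > 10000 nM, which is a limit of the assay and not a number. As far as these compounds go, the full size of the step therefore stays unknown, and it can be read only as a minimum: the limit of > 10000 nM in this assay, at which 1 of the 3 values shown sits.

The compounds shown leave open which part of the swap carries the step, as a (3-hydroxypropyl)sulfanyl chain or a carbamoyl chain without the methyl on its nitrogen would separate the parts. They also do not tell how a chain ending in an amine or a carboxylic acid instead of the hydroxyl would fare at this position.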